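Chloro to Methoxy Exchange Repeated on a Second Core

The source may hold more compounds than are shown below. What is called first, only, known or untested is meant among the compounds shown, and "the series" means these compounds.

Measured in a functional assay on HepG2 cells (Homo sapiens) for cytotoxicity, read by MTT assay, with a stated time of 72 h; a lower number here means a stronger inhibitor, a higher number a weaker inhibitor:
compound 1 `O=C(Nc1ccc(Oc2ccnc3[nH]ccc23)c(F)c1)c1nn(-c2ccc(Cl)cc2)ccc1=O` gives > 60000 nM.
compound 2 `COc1ccc(-n2ccc(=O)c(C(=O)Nc3ccc(Oc4ccnc5[nH]ccc45)c(F)c3)n2)cc1` gives > 60000 nM.
compound 3 `Cn1ccc2c(Oc3ccc(NC(=O)c4nn(-c5ccc(Cl)cc5)ccc4=O)cc3)ccnc21` gives > 60000 nM.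

For compound 3 this value is a limit of the assay. For compound 2 the value is likewise a limit. For compound 1 the value is a limit as well. All three sit at the limit of > 60000 nM in this assay, at which 3 of the 3 values shown sit.

From compound 1 to compound 2 the change is methoxy in place of chloro on an aromatic carbon, and the step it made is a step that the two limits leave unreadable from compound 1 to compound 2. How the core of compound 3 differs from that of compound 1 is not broken down here.

Compound 4 `COc1ccc(-n2ccc(=O)c(C(=O)Nc3ccc(Oc4ccnc5c4ccn5C)cc3)n2)cc1` is not yet measured. It differs from compound 3 by methoxy in place of chloro on an aromatic carbon, the same change as from compound 1 to compound 2. Because both compound 1 and compound 2 sit at the limit of > 60000 nM in this assay, at which 3 of the 3 values shown sit, the step that the limit leaves unreadable from compound 3 to compound 4 is expected to stay unreadable, most likely another limit. Compound 4 is estimated at 90000 nM, between 30000 nM and 400000 nM.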

Compound 4, half-maximal inhibitory concentration: > 60000 nM
Compound 4: only a limit was reported; the forecaster's own chance of this, stated with the estimate: 85%; the middle value lies beyond the limit too.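

The step from compound 3 to compound 4 cannot be read, as both values are limits of the assay: the limit of > 60000 nM in this assay, at which 4 of the 4 values shown sit.

The compounds shown leave open whether methoxy in place of chloro changes cytotoxicity on either core, as none gives a measured number.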